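Trimethoxyphenyl series: removing one methoxy, cytotoxicity expectation

A few compounds are considered here, and "the series" means these few. Any claim that something is new, unique, unknown or untested is made for them only; others in the source may bear on it.

Measured compounds:
- compound 1 `COc1cc(C2CC(c3cc4ccccc4nc3C)=NN2C(C)=O)cc(OC)c1OC`: > 200 ug/mL
- compound 2 `COc1cc(C2CC(c3cc4ccccc4nc3C)=NN2c2ccccc2)cc(OC)c1OC`: > 200 ug/mL
- compound 3 `Cc1nc2ccccc2cc1-c1nnc(-c2cn(-c3ccccc3)nc2-c2ccccc2)o1`: > 200 ug/mL

In an ADME assay on A549 cells (Homo sapiens) for cytotoxicity, read by MTT assay, with a stated time of 48 h (on this read-out lower numbers stand for stronger inhibition and higher numbers for weaker inhibition), compound 1 gives > 200 ug/mL, which is a limit of the assay and not a number. Compound 2 also sits at a limit in this assay, > 200 ug/mL. Compound 3 likewise gives only a limit, > 200 ug/mL. Among the compounds with values here, the one step between measured compounds, a step that the two limits leave unreadable from compound 1 to compound 2, is therefore not readable in size, since both ends are limits. Within the data shown here, the whole picture is summarised by the limit of > 200 ug/mL in this assay, at which 3 of the 3 values shown sit: no measured compound yields a number in this assay.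

Compound 4 `COc1ccc(C2CC(c3cc4ccccc4nc3C)=NN2C(C)=O)cc1OC` differs from compound 1 by hydrogen in place of methoxy on an aromatic carbon. Among the measured compounds shown here, no measured step reports the effect of dropping a methoxy from this ring, and the only step available is unreadable, so nothing bears directly on the change.

Given that every compound so far, including compound 1 with > 200 ug/mL, sits at the limit, compound 4 is expected to remain there too, with an expected step that the limit leaves unreadable from compound 1 to compound 4 that is not beyond the scatter. The estimate for compound 4 is 250 ug/mL, between 90 ug/mL and 700 ug/mL.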

Compound 4, half-maximal inhibitory concentration: > 200 ug/mL
Compound 4: no number, only a limit; the forecaster's own chance of this, stated with the estimate: 75%; the middle value is on the limit's open side.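

In this assay compound 4 gives > 200 ug/mL, which is a limit and not a number. Compound 1 also stands at a limit, so the step between compound 1 and compound 4 cannot be read. The compounds shown leave open how far removing a methoxy changes cytotoxicity, and whether any change to the core yields a number: the limit of > 200 ug/mL in this assay, at which 4 of the 4 values shown sit.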